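Swapping phenyl for pyridine on the amide arm

A few compounds are considered here, and "the series" means these few. Any claim that something is new, unique, unknown or untested is made for them only; others in the source may bear on it.

Compound 2 `CN(C)CCN1CCN(C2=Nc3ccccc3C(CC(=O)NCc3ccccc3)N2c2ccc(-c3ccccc3)cc2)CC1` is one of three related compounds tested in a functional assay on A2780 cells (Homo sapiens) for cytotoxicity, read by MTT assay, with a stated time of 48 h; on this read-out higher numbers stand for weaker inhibition and lower numbers for stronger inhibition. In this assay compound 2 gives 1390 nM. Compound 1 `COc1ccc(CNC(=O)CC2c3ccccc3N=C(N(C)CCCCCN(C)C)N2c2ccc(-c3ccccc3)cc2)cc1` gives 1380 nM, and the two numbers lie within the scatter of each other, so neither can be called the more potent. Compound 3 `CN(C)CCN1CCN(C2=Nc3ccccc3C(CC(=O)NCc3ccccc3)N2c2ccc(-c3ccccn3)cc2)CC1` is reported only as a limit of the assay, > 5000 nM. The change from compound 2 to compound 3, pyridin-2-yl in place of phenyl on an aromatic carbon, gave an at least 3.5-fold higher number from compound 2 to compound 3 (0.55 log units; beyond the scatter); this rests on (the limit of > 5000 nM in this assay, at which 1 of the 3 values shown sits), so only a lower bound of the weakening is known.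

Compound 4 `CN(C)CCN1CCN(C2=Nc3ccccc3C(CC(=O)NCc3ccncc3)N2c2ccc(-c3ccccc3)cc2)CC1` has not been measured yet. It differs from compound 2 by pyridin-4-yl in place of phenyl on a saturated chain carbon bound to an amide-type nitrogen. Among the measured compounds shown here, the only measured step that bears on this, the one from compound 2 to compound 3, also exchanges phenyl for a pyridyl ring, but on a different part of the molecule, so it is a loose guide. On that guide a modest weakening is expected rather than none. The expected step is therefore a 1.8-fold higher number from compound 2 to compound 4 (0.25 log units; within the scatter). For compound 4 the value in this assay is estimated at 2500 nM, expected to fall between 1000 nM and 7000 nM.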

Compound 4, half-maximal inhibitory concentration: > 5000 nM
Compound 4: only a limit was reported (the forecaster's own chance of this, stated with the estimate: 25%); middle value at least 2.0-fold (0.30 log units) away from the limit.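

Among the compounds shown here, until now, the only exchange of phenyl for a pyridine ring lay on a different part of the molecule; this result shows that the amide arm responds as well, with benzyl to (pyridin-4-yl)methyl giving an at least 3.5-fold higher number from compound 2 to compound 4 (0.55 log units; beyond the scatter) in this assay. Compound 4 stands at > 5000 nM, which is a limit of the assay and not a number. Each of the two pyridine exchanges, on either part of the molecule, therefore weakens compound 2 beyond the scatter, but the true size of neither step is known: the limit of > 5000 nM in this assay, at which 2 of the 4 values shown sit.

The compounds shown leave open whether this loss appears with the ring nitrogen at any ring position, as a pyridin-3-yl group on this arm would test, or whether a cyclohexyl group there would keep the level of compound 2. A compound on this arm with a value inside the range of the assay would also give the real size of a step at this position, which compound 4 cannot do.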